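The source may hold more compounds than are shown below. What is called first, only, known or untested is meant among the compounds shown, and "the series" means these compounds.

Working notes on the series.

Compound 1 `COc1ccc(/C=C/C(=O)C(=Cc2cccc(F)c2)C(=O)/C=C/c2ccc(OC)c(OC)c2)cc1OC` and compound 2 `CCc1ccc(C=C(C(=O)/C=C/c2ccc(OC)c(OC)c2)C(=O)/C=C/c2ccc(OC)c(OC)c2)cc1` share one core, while compound 3 `COc1cc(/C=C/C(=O)C(=Cc2cccc(F)c2)C(=O)/C=C/c2ccc(O)c(OC)c2)ccc1O` and compound 4 `CCc1ccc(C=C(C(=O)/C=C/c2ccc(O)c(OC)c2)C(=O)/C=C/c2ccc(O)c(OC)c2)cc1` share another; the difference between the two cores is not broken down here. In a functional assay on A549 cells (Homo sapiens) for inhibition, read by sulforhodamine B assay, with a stated time of 48 h (a lower number here means a stronger inhibitor of growth, a higher number a weaker inhibitor of growth), compound 1 gives 580 nM. In this assay compound 2 gives 630 nM. In this assay compound 3 gives 360 nM. Compound 4 has not yet been measured in this assay.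

The change from compound 1 to compound 2 is 4-ethylphenyl in place of 3-fluorophenyl on a double-bonded chain carbon bound to a double-bonded chain carbon. It made a 1.1-fold higher number from compound 1 to compound 2 (0.04 log units; within the scatter), so on the core of compound 1 this change left the growth inhibition essentially unchanged. The change from compound 3 to compound 4 is 4-ethylphenyl in place of 3-fluorophenyl on a double-bonded chain carbon bound to a double-bonded chain carbon, the same change, made at the same place, on the core of compound 3. Among the compounds shown it occurs in these two pairs only, so the one measured step is all there is to lean on. The values of compound 3 and compound 1 lie within the scatter of each other, as do those of compound 3 and compound 2, so no ordering among the measured compounds is claimed.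

Compound 4 is expected at 400 nM, with a range from 200 nM to 800 nM. The expected step of a 1.1-fold higher number from compound 3 to compound 4 (0.05 log units; within the scatter) is set beside the measured one because a 1.1-fold higher number from compound 1 to compound 2 (0.04 log units; within the scatter) is what the same change made on the other core. The range is kept wide, since the change has been seen only once and the cores differ in more than one place.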

Compound 4, concentration for 50% growth inhibition: 550 nM
Compound 4: the middle estimate sits 1.4-fold (0.14 log units) below what was measured; measured number inside the range.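

In this assay, 4-ethylphenyl in place of 3-fluorophenyl on the core of compound 3 gives a 1.5-fold higher number from compound 3 to compound 4 (0.18 log units; within the scatter), so here too the change leaves the growth inhibition essentially unchanged. Set side by side, the two steps do not differ: the same change on two cores in this assay, a 1.1-fold higher number (0.04 log units; within the scatter) from compound 1 to compound 2 and a 1.5-fold higher number (0.18 log units; within the scatter) from compound 3 to compound 4, 1.4-fold (0.15 log units) apart, within the scatter of two such steps

Within these four compounds, then, the change carries from one core to the other as a step inside the scatter on both, which is agreement between two small steps and no more; it does not show that the same would hold on any further core, and it gives no reason for the result.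

The compounds shown hold only 3-fluorophenyl and 4-ethylphenyl at this place, so it stays open whether a phenyl ring bearing an amine, a carboxylic acid or a longer chain would also stay within the scatter on both cores. Also open is what the difference between the two cores does on its own, as the compounds shown do not break that difference down into single changes.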